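A few compounds are considered here, and "the series" means these few. Any claim that something is new, unique, unknown or untested is made for them only; others in the source may bear on it.

In a functional assay on HepG2 cells (Homo sapiens) for cytotoxicity, read by MTT assay, with a stated time of 48 h (on this read-out lower numbers stand for stronger inhibition and higher numbers for weaker inhibition), three compounds sharing one core have been measured. Compound 1 `CCC(=O)N1N=C(c2cc3ccccc3oc2=O)CC1c1ccccc1` gives 9610 nM, compound 2 `CC(C)CNCC(=O)N1N=C(c2cc3ccccc3oc2=O)CC1c1ccccc1` gives 9970 nM and compound 3 `CC(C)(C)NCC(=O)N1N=C(c2cc3ccccc3oc2=O)CC1c1ccccc1` gives 31400 nM. Compound 3 thus has the highest number of the three and is the weakest inhibitor of this small set.

The next compound is compound 4 `CC1CCCN(CC(=O)N2N=C(c3cc4ccccc4oc3=O)CC2c2ccccc2)C1`, which has 3-methylpiperidin-1-yl in place of (tert-butyl)amino on a saturated chain carbon bound to a carbonyl carbon.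

For the measured compounds named here, three measured steps bear on this change. The closest is a 3.1-fold higher number from compound 2 to compound 3 (0.50 log units; beyond the scatter), where tert-butyl takes the place of isobutyl on an amine nitrogen. The others are a 3.3-fold higher number from compound 1 to compound 3 (0.51 log units; beyond the scatter) and a 1.0-fold higher number from compound 1 to compound 2 (0.02 log units; within the scatter). Among these compounds, only the one with the (tert-butyl)amino group stands apart, so its removal is expected to bring a modest move towards lower numbers. Going by the values given here, no measured compound carries a ring at this place, however, which leaves the size of the step uncertain.

The expected result is a 2.1-fold lower number from compound 3 to compound 4 (0.32 log units; beyond the scatter). For compound 4 the estimated value is 15000 nM, with an expected range from 6000 nM to 35000 nM.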

Compound 4, half-maximal inhibitory concentration: "not active" (no number reported)
No number was reported for compound 4; there is nothing to compare the estimate with.
By their numbers in this assay, from the lowest: compounds 1 and 2 (each within the scatter of the next); then compound 3.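

In this assay, for the compounds shown here, compound 4 is reported as "not active", without a number, so no step linking it to compound 1, compound 2 or compound 3 can be read. Nothing at hand explains this result. The compounds shown leave open what number, if any, a ring such as 3-methylpiperidin-1-yl gives at this place.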